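Replacing a Pentyl Chain with a Benzyl Group

The source may hold more compounds than are shown below. What is called first, only, known or untested is meant among the compounds shown, and "the series" means these compounds.

Compound 3 `CCCCCNc1nc(SCc2ccc([N+](=O)[O-])cc2)c2ncn([C@@H]3O[C@H](CO)[C@@H](O)[C@H]3O)c2n1` gives the highest of the three numbers measured in an assay on K562 cells for displacement of a labelled ligand from Equilibrative nucleoside transporter 1 (Homo sapiens), read by flow cytometry, with a stated time of 45 min; on this read-out lower numbers stand for stronger inhibition and higher numbers for weaker inhibition: compound 3 gives 357 nM, compound 2 `CCCCNc1nc(SCc2ccc([N+](=O)[O-])cc2)c2ncn([C@@H]3O[C@H](CO)[C@@H](O)[C@H]3O)c2n1` gives 325 nM, and compound 1 `O=[N+]([O-])c1ccc(CSc2nc(NC3CC3)nc3c2ncn3[C@@H]2O[C@H](CO)[C@@H](O)[C@H]2O)cc1` gives 25 nM. The step of a 1.1-fold higher number from compound 2 to compound 3 (0.04 log units; within the scatter) lies within the scatter, whereas the steps of a 13-fold higher number from compound 1 to compound 2 (1.11 log units; beyond the scatter) and a 14-fold higher number from compound 1 to compound 3 (1.15 log units; beyond the scatter) set compound 1 clearly apart from the two chain-bearing compounds. Compound 4 `O=[N+]([O-])c1ccc(CSc2nc(NCc3ccccc3)nc3c2ncn3[C@@H]2O[C@H](CO)[C@@H](O)[C@H]2O)cc1` carries phenyl in place of butyl on a saturated chain carbon bound to a nitrogen on an aromatic ring. Two kinds of measured step bear on this change: the step of a 1.1-fold higher number from compound 2 to compound 3 (0.04 log units; within the scatter) shows that one more carbon on the chain changes nothing beyond the scatter, while the steps of a 13-fold higher number from compound 1 to compound 2 (1.11 log units; beyond the scatter) and a 14-fold higher number from compound 1 to compound 3 (1.15 log units; beyond the scatter) show that the cyclopropyl of compound 1 gives a much lower number than either chain. Among the measured compounds shown here, no measured step puts an aromatic ring on the chain, so the benzyl case remains open. A modest move toward a lower number is expected, a 2.4-fold lower number from compound 3 to compound 4 (0.38 log units; beyond the scatter), with wide uncertainty. Compound 4 is therefore estimated at 150 nM in this assay, within a range from 30 nM to 800 nM.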

Compound 4, inhibition constant: 247 nM
Estimate against measurement, compound 4: 1.6-fold (0.22 log units) below; the measured number falls inside the stated range.
By their numbers in this assay, from the lowest: compound 1; then compounds 4, 2 and 3 (each within the scatter of the next).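

In this assay, the benzyl group of compound 4 cannot be told apart from the straight chains: pentyl gives way to benzyl with (a 1.4-fold lower number from compound 3 to compound 4 (0.16 log units; within the scatter)), and the butyl compound gives way to it with (a 1.3-fold lower number from compound 2 to compound 4 (0.12 log units; within the scatter)). Putting a six-membered aromatic ring on the saturated chain carbon therefore does not bring the number near that of the cyclopropyl compound, as the step (a 9.9-fold higher number from compound 1 to compound 4 (0.99 log units; beyond the scatter)) shows. No evidence at hand accounts for the place of cyclopropyl apart from these three groups.

The compounds shown leave open whether another saturated ring on this nitrogen, such as cyclobutyl or cyclopentyl, would share the low number of compound 1. They also leave open whether a shorter chain, such as ethyl, would stay with butyl and pentyl.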